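Ester to amide at the carbonyl of compound 3

A few compounds are considered here, and "the series" means these few. Any claim that something is new, unique, unknown or untested is made for them only; others in the source may bear on it.

Three compounds of the shared core carry numbers in an assay on isolated protein for inhibition of Gonadotropin-releasing hormone receptor (Homo sapiens); a lower number here means a stronger inhibitor, a higher number a weaker inhibitor. Within the data shown here, compound 1 `COc1ccc([N+](=O)[O-])cc1CSc1nc2cc(NC(=O)NC(C)(C)C)ccc2n1Cc1ccccc1` gives 28 nM and compound 2 `COc1ccc([N+](=O)[O-])cc1CSc1nc2cc(NC(=O)NC(C)(C)C)ccc2n1C(C)C` gives 62 nM; the one step counted between them, a 2.2-fold higher number from compound 1 to compound 2 (0.35 log units; beyond the scatter), swaps the group on the aromatic nitrogen. Compound 3 `CCCn1c(SCc2cc([N+](=O)[O-])ccc2OC)nc2cc(NC(=O)NC(C)(C)C)cc(C(=O)OC)c21` gives 37 nM; it stands second highest of the three, yet its distances to compound 1 and to compound 2 both fall within the scatter, so no order among the three is claimed.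

Compound 4 `CCCn1c(SCc2cc([N+](=O)[O-])ccc2OC)nc2cc(NC(=O)NC(C)(C)C)cc(C(=O)NCc3cccnc3)c21` differs from compound 3 in one place: ((pyridin-3-yl)methyl)amino in place of methoxy on a carbonyl carbon. Among the measured compounds shown here, no measured step touches the carbonyl carbon; the only step in hand sits on the aromatic nitrogen and says nothing about this position. For the measured compounds named here, with no bearing step, no direction beyond the scatter is expected, and the uncertainty is set wide. The step from compound 3 to compound 4 is therefore estimated as a 1.1-fold higher number from compound 3 to compound 4 (0.03 log units; within the scatter), and compound 4 is expected near 40 nM, within the range 10 nM to 160 nM in this assay.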

Compound 4, half-maximal inhibitory concentration: 69 nM
Compound 4: the middle estimate sits 1.7-fold (0.24 log units) below what was measured; low and high end bracket the measured number.
By their numbers in this assay, from the lowest: compounds 1, 3, 2 and 4 (each within the scatter of the next, the first and the last beyond it).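

In this assay, the carbonyl carbon now has its first readable step: ((pyridin-3-yl)methyl)amino in place of methoxy gives a 1.9-fold higher number from compound 3 to compound 4 (0.27 log units; within the scatter). The exchange turns the ester into an amide and brings in a six-membered aromatic ring with 1 hetero atom and a hydrogen-bond donor, yet this single step does not separate the two groups, so the position accepts this much larger substituent without a change that can be read beyond the scatter. No supporting measurement is available to interpret this step further.

Open at this carbonyl carbon is how a carboxylic acid, a plain unsubstituted amide or a benzyl amide would read. Also open, on these data alone, is whether the same exchange reads alike with benzyl rather than propyl on the aromatic nitrogen.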